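Benzyl para substituent: chloro to nitro on the shared core

The source may report more compounds than this note shows. Statements on the series, on what has been measured and on what is new or still open speak of the compounds shown alone.

Measured so far:
compound 1 `NC(=O)c1c(NC(=O)c2ccccc2Cl)sc2c1CCN(Cc1ccccc1)C2` — in a functional assay on HL-60 cells (Homo sapiens) for antiproliferative activity, with a stated time of 24 h (on this read-out higher numbers stand for weaker inhibition and lower numbers for stronger inhibition), compound 1 gives 12000 nM
compound 2 `NC(=O)c1c(NC(=O)c2ccccc2Cl)sc2c1CCN(Cc1ccc(Cl)cc1)C2` — in this assay compound 2 gives 22500 nM

Compound 2 holds the highest of the two numbers; its nearest neighbour is compound 1, reached by the step of a 1.9-fold higher number from compound 1 to compound 2 (0.27 log units; within the scatter). Compound 3 `NC(=O)c1c(NC(=O)c2ccccc2Cl)sc2c1CCN(Cc1ccc([N+](=O)[O-])cc1)C2` differs from compound 2 by nitro in place of chloro on an aromatic carbon. For the measured compounds named here, the single measured step concerns the same aromatic carbon and stayed within the scatter, so no step beyond the scatter is expected in this assay for the nitro exchange either. Compound 3 is estimated at 20000 nM, range 8000 nM to 50000 nM. The expected step is a 1.1-fold lower number from compound 2 to compound 3 (0.05 log units; within the scatter).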

Compound 3, half-maximal inhibitory concentration: 11400 nM
Compound 3: middle estimate off by 1.8-fold (0.24 log units), on the high side, and the stated range covers the measured number.
By their numbers in this assay, from the lowest: compounds 3, 1 and 2 (each within the scatter of the next).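

In this assay, nitro in place of chloro gives a 2.0-fold lower number from compound 2 to compound 3 (0.30 log units; within the scatter), and nitro in place of hydrogen gives a 1.1-fold lower number from compound 1 to compound 3 (0.02 log units; within the scatter). At this aromatic carbon, a second substituent, nitro, with 3 heavy atoms and 2 hydrogen-bond acceptors, also yields no step beyond the scatter, so hydrogen, chloro and nitro cannot be ranked here. No measured evidence that could explain this result is available. As far as these compounds go, whether an amine or a carboxylic acid at this carbon would give a step beyond the scatter stays open. So does the outcome of replacing benzyl with a longer chain.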